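The compounds below may be only part of what the source reports. "The series", "measured", "known", "first", "only" and "open" are said of these compounds alone.

Measured so far in an ADME assay on NIH3T3 cells (Mus musculus) for cytotoxicity, read by XTT assay, with a stated time of 24 h; a higher number here means a weaker inhibitor, a lower number a stronger inhibitor:

Compound 1 `Cc1ccc(-c2csc(N3N=C(c4ccc(C)s4)CC3c3ccc(F)cc3)n2)cc1` is recorded only as the limit > 500 ug/mL.
Compound 2 `COc1ccc(-c2csc(N3N=C(c4ccc(C)s4)CC3c3ccc(F)cc3)n2)cc1` gives 147 ug/mL.
Compound 3 `O=[N+]([O-])c1ccc(-c2csc(N3N=C(c4ccc(Cl)s4)CC3c3ccc(F)cc3)n2)cc1` is recorded only as the limit > 500 ug/mL.

Compound 1 therefore has no number of its own in this assay, only a limit, and it shares that position with compound 3, as the limit of > 500 ug/mL in this assay, at which 2 of the 3 values shown sit, shows. Within the data shown here, compound 2 is the only member of the series with a measured value.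

Compound 4 `Cc1ccc(C2=NN(c3nc(-c4ccc(S(C)(=O)=O)cc4)cs3)C(c3ccc(F)cc3)C2)s1` differs from compound 1 in one place: methylsulfonyl in place of methyl on an aromatic carbon.

Among the measured compounds shown here, only one measured step bears on this change, and only loosely. Going an at least 3.4-fold lower number from compound 1 to compound 2 (0.53 log units; beyond the scatter), the same aromatic carbon carries methoxy in place of methyl, and the number moves from the limit to a measured value. Methylsulfonyl is a different group from methoxy, so that step gives direction rather than size. For the measured compounds named here, compound 3 offers no step to compound 1, since it differs in more than one place; its limit value shows only that the limit is common.

Expectation: a lower number than the limit is possible, but a further limit is nearly as likely. The estimate for compound 4 in this assay is 350 ug/mL. Its expected range is estimated to run from 120 ug/mL to 600 ug/mL. This corresponds to an expected at least 1.4-fold lower number from compound 1 to compound 4 (0.15 log units; that floor lies within the scatter).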

Compound 4, half-maximal inhibitory concentration: 374 ug/mL
Compound 4: middle estimate off by 1.1-fold (0.03 log units), on the low side; the range from low to high includes it.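

The aromatic carbon para to a large group now carries a second substituent that gives a measured value in this assay, so a number at this position no longer rests on methoxy alone. Between the two measured groups the change reads as a 2.5-fold higher number from compound 2 to compound 4 (0.41 log units; beyond the scatter), the first comparison at this position between two real numbers, and it shows that methoxy and methylsulfonyl are not interchangeable here in this read-out. Against methyl the reading is much weaker, an at least 1.3-fold lower number from compound 1 to compound 4 (0.12 log units; that floor lies within the scatter), and that figure is only a floor, so the true size of this change is not fixed.

The methyl end of the comparison stays open, with compound 1 held as a limit and not a number, and such limits are common in this small set: the limit of > 500 ug/mL in this assay, at which 2 of the 4 values shown sit.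

Also open, on these data alone, is how an amine or a carboxylic acid on the same aromatic carbon would read, and whether the gap between methoxy and methylsulfonyl holds when another part of the shared core changes.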